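The compounds below may be only part of what the source reports. "The series", "measured", "known", "first", "only" and "open" are said of these compounds alone.

Measured so far:
- compound 1 `CN1CCC(Oc2ccc(N3C(=S)N(c4cnc(C#N)c(C(F)(F)F)c4)C(=O)C34CCC4)cn2)CC1`: 10900 ng.h/mL
- compound 2 `Cc1cc(N2C(=O)C3(CCC3)N(c3ccc(OC4CCNCC4)nc3)C2=S)cnc1C#N`: 7800 ng.h/mL

Both compounds were tested in an ADME assay on the whole organism (Mus musculus, strain CD1) for pharmacokinetics, at a dose of 10 mg/kg by the oral route; a higher number here means more compound in the circulation at the dose given, a lower number less compound in the circulation. In this assay, compound 2 gives 7800 ng.h/mL and compound 1 gives 10900 ng.h/mL. These two numbers lie within the usual scatter of each other, so the data do not separate the two compounds.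

The next compound to be measured is compound 3 `N#Cc1ncc(N2C(=O)C3(CCC3)N(c3ccc(OC4CCNCC4)nc3)C2=S)cc1Cl`. It has chloro in place of methyl on an aromatic carbon, a change from 6-cyano-5-methylpyridin-3-yl to 5-chloro-6-cyanopyridin-3-yl (chloro in place of methyl on an aromatic carbon). The swap sits ortho to a cyano group and leaves the rest of compound 2 as it was.

Among the compounds with values here, no measured pair here shows a single change on its own, so the data give no direct guide to the effect of this swap in this assay. The expectation therefore starts from compound 2 at 7800 ng.h/mL, and no step beyond the scatter is expected. The estimated step, a 1.1-fold lower number from compound 2 to compound 3 (0.05 log units; within the scatter), stays within that scatter. The estimate for compound 3 is 7000 ng.h/mL, with an expected range from 3000 ng.h/mL to 16000 ng.h/mL.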

Compound 3, area under the concentration-time curve: 6000 ng.h/mL
Estimate against measurement, compound 3: 1.2-fold (0.07 log units) above, and the stated range covers the measured number.
By their numbers in this assay, from the lowest: compounds 3, 2 and 1 (each within the scatter of the next).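

In this assay the swap of methyl for chloro on an aromatic carbon, ortho to a cyano group, gives a 1.3-fold lower number from compound 2 to compound 3 (0.11 log units; within the scatter) and so does not separate the two compounds. Within the data shown here, this is the first pair here that differs in one place only, which lets this position be read on its own for the first time: at this dose, chloro and methyl cannot be told apart by the amount of compound in the circulation. The data offer no measured explanation for this result, and no measured property of either group bears on it.

The trifluoromethyl group of compound 1 sits on the same ring, but compound 1 also differs from compound 2 elsewhere, so the effect of that group cannot be read alone. Going by these compounds, whether the position stays this undemanding with a fluoro, a methoxy or a plain hydrogen in place of chloro remains open, as does whether the same swap would behave alike on another version of the core.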